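Shorter Alkyl Chain on the Core of Compound 3

A few compounds are considered here, and "the series" means these few. Any claim that something is new, unique, unknown or untested is made for them only; others in the source may bear on it.

Three compounds were tested in a functional assay on UMUC3 cells (Homo sapiens) for antiproliferative activity, read by MTT assay, with a stated time of 72 h; a lower number here means a stronger inhibitor, a higher number a weaker inhibitor. Compound 1 `CC(C)NC(=N)NC(=N)Nc1ccc(C(F)(F)F)cc1` gives 5200 nM in this assay. Compound 2 `CC(C)CNC(=N)NC(=N)Nc1ccc(C(F)(F)F)cc1` gives 2000 nM. Compound 3 `CC(C)CNC(=N)NC(=N)Nc1ccc(F)c(F)c1` gives 7100 nM, and its value against compound 1 lies within the scatter, while against compound 2 it stands beyond it. The difference between the core of compound 3 and the core of compound 2 is not broken down here.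

Between compound 2 and compound 1 the change is isopropyl in place of isobutyl on an amine nitrogen, and it produced a 2.6-fold higher number from compound 2 to compound 1 (0.41 log units; beyond the scatter). Compound 4 `CC(C)NC(=N)NC(=N)Nc1ccc(F)c(F)c1` has not yet been measured; it differs from compound 3 by isopropyl in place of isobutyl on an amine nitrogen, the same kind of change on the same place.

Among the measured compounds shown here, with only this one earlier step to rest on, compound 4 is expected to show a 2.4-fold higher number from compound 3 to compound 4 (0.38 log units; beyond the scatter) in this assay, because the earlier step gave a 2.6-fold higher number from compound 2 to compound 1 (0.41 log units; beyond the scatter). Compound 4 is therefore estimated at 17000 nM, with a likely range from 7000 nM to 40000 nM.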

Compound 4, half-maximal inhibitory concentration: 25000 nM
Compound 4: middle estimate off by 1.5-fold (0.17 log units), on the low side; the measured number falls inside the stated range.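

In this assay, isopropyl in place of isobutyl on the amine nitrogen again gave a weaker compound on the core of compound 3, with a 3.5-fold higher number from compound 3 to compound 4 (0.55 log units; beyond the scatter). The change thus carried from one core to the other with the same direction and, within the scatter, the same size: the same change on two cores in this assay, a 2.6-fold higher number (0.41 log units; beyond the scatter) from compound 2 to compound 1 and a 3.5-fold higher number (0.55 log units; beyond the scatter) from compound 3 to compound 4, 1.4-fold (0.13 log units) apart, within the scatter of two such steps. This agreement rests on just these two matched pairs in a single cell assay, and it does not show that the step would hold on any other core, nor does it explain why activity falls.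

Only isobutyl and isopropyl appear on this amine nitrogen, which leaves open how a longer chain such as n-hexyl or a cyclohexyl group would behave there. Going by these compounds, it also remains open whether the step would keep its size on a core bearing a nitrile or a methoxy group instead of the trifluoromethyl group or the fluorine atoms.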